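Para substituent swap on the thiourea series: amine to amide

This account rests on a few compounds, and the source may have more. Where it says the series, first, only, none or still open, it means among the compounds named here.

Among the compounds with values here, compound 2 `CCN(CC)c1ccc(NC(=S)N2CCC(C(O)(c3ccccc3)c3ccccc3)CC2)cc1` gives 72 nM in a functional assay for antagonist activity at Neuropeptide Y receptor type 2 (Homo sapiens) (on this read-out lower numbers stand for stronger inhibition and higher numbers for weaker inhibition), the lowest of the two numbers known; compound 1 `CN(C)c1ccc(NC(=S)N2CCC(C(O)(c3ccccc3)c3ccccc3)CC2)cc1` gives 612 nM. Within the data shown here, the only measured step, an 8.5-fold lower number from compound 1 to compound 2 (0.93 log units; beyond the scatter), involved the same position. Compound 3 `CCNC(=O)c1ccc(NC(=S)N2CCC(C(O)(c3ccccc3)c3ccccc3)CC2)cc1` carries the change (ethylcarbamoyl in place of diethylamino on an aromatic carbon). Among the measured compounds shown here, no measured step covers an amine-to-amide exchange, so the direction rests on the amine being the only group seen at this position; a higher number for compound 3 is expected, of size a 9.7-fold higher number from compound 2 to compound 3 (0.99 log units; beyond the scatter). The estimate for compound 3 is 700 nM, with a range of 150 nM to 3500 nM.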

Compound 3, half-maximal inhibitory concentration: 206 nM
Estimate against measurement, compound 3: 3.4-fold (0.53 log units) above; the measured number falls inside the stated range.
By their numbers in this assay, from the lowest: compound 2; then compound 3; then compound 1.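

In this assay this position proves not to be limited to amines: ethylcarbamoyl keeps measurable inhibition, though the step to it shows a 2.9-fold higher number from compound 2 to compound 3 (0.46 log units; beyond the scatter) and diethylamino stays ahead. Against dimethylamino the order reverses, with a 3.0-fold lower number from compound 1 to compound 3 (0.47 log units; beyond the scatter) and compound 3 falling between the two amines. No evidence is available to explain either step.

Open, going by these compounds, is whether a diethylcarbamoyl group or a carboxylic acid would place nearer compound 2 or compound 1. Also open, on these data alone, is whether a dipropylamino group would extend the gain seen from dimethylamino to diethylamino.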